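The source may report more compounds than this note shows. Statements on the series, on what has been measured and on what is new or still open speak of the compounds shown alone.

Measured compounds in a functional assay on MDA-MB-231 cells (Homo sapiens) for inhibition, read by MTT assay, with a stated time of 72 h; a lower number here means a stronger inhibitor, a higher number a weaker inhibitor:
- compound 1, `C=CC(=O)Nc1cccc(NC(=O)CSc2nc(Nc3ccccc3F)c3ccccc3n2)c1`, gives 18700 nM
- compound 2, `C=CC(=O)Nc1cccc(NC(=O)CSc2nc(Nc3cccc(F)c3)c3ccccc3n2)c1`, gives 8160 nM
- compound 3, `C=CC(=O)Nc1cccc(NC(=O)CSc2nc(Nc3ccc(F)cc3)c3ccccc3n2)c1`, gives 9490 nM

Compound 3 stands second highest of the three numbers in this assay. Its nearest neighbour is compound 2, and the gap between them, a 1.2-fold higher number from compound 2 to compound 3 (0.07 log units; within the scatter), lies within the scatter. Compound 1 is the furthest away, yet the step of a 2.0-fold lower number from compound 1 to compound 3 (0.29 log units; within the scatter) also stays within the scatter. Among the compounds with values here, the one step that reaches beyond the scatter is a 2.3-fold lower number from compound 1 to compound 2 (0.36 log units; beyond the scatter), which moves fluorine from one position of the phenyl on the nitrogen to another.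

Compound 4, `C=CC(=O)Nc1cccc(NC(=O)CSc2nc(Nc3cc(OC)c(OC)c(OC)c3)c3ccccc3n2)c1`, is not yet measured. Compared with compound 3 it carries 3,4,5-trimethoxyphenyl in place of 4-fluorophenyl on a nitrogen on an aromatic ring. Within the data shown here, none of the measured steps bears directly on this change: all three steps only shift a single fluorine around the same phenyl, and the largest of them is modest. Among the measured compounds shown here, there is no measured pair in which the substituent count or the number of hydrogen-bond acceptors on this ring changes, so the direction of the step in this assay for compound 4 cannot be read from the data.

Accordingly, the expected step from compound 3 to compound 4 is set near zero, a 1.4-fold lower number from compound 3 to compound 4 (0.13 log units; within the scatter), with a wide uncertainty. Compound 4 is estimated at 7000 nM, with the range 1500 nM to 30000 nM.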

Compound 4, half-maximal inhibitory concentration: > 50000 nM
Compound 4: no number, only a limit; the forecaster's own chance of this, stated with the estimate: 10%; middle value at least 7.1-fold (0.85 log units) from the limit.
By their numbers in this assay, from the lowest: compounds 2, 3 and 1 (each within the scatter of the next, the first and the last beyond it). At a limit, above all of these: compound 4.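

Compound 4 gives no number in this assay, only a limit: the limit of > 50000 nM in this assay, at which 1 of the 4 values shown sits. The group on this nitrogen therefore matters in a way the fluorine shifts could not show, as 3,4,5-trimethoxyphenyl gives an at least 5.2-fold higher number from compound 3 to compound 4 (0.72 log units; beyond the scatter), an at least 6.1-fold higher number from compound 2 to compound 4 (0.78 log units; beyond the scatter) and an at least 2.6-fold higher number from compound 1 to compound 4 (0.42 log units; beyond the scatter), so the number rises against all three fluorophenyl compounds. Within the data shown here, until now, the only step beyond the scatter was the shift of a single fluorine, a 2.3-fold lower number from compound 1 to compound 2 (0.36 log units; beyond the scatter), and the new result shows that replacing the whole group can also weaken inhibition in this assay, with the true size of the loss hidden behind the limit.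

The change swaps 7 heavy atoms and 0 hydrogen-bond acceptors for 12 heavy atoms and 3 hydrogen-bond acceptors in one step, so the compounds shown cannot separate the effect of the number of methoxy groups from that of their placement or of the loss of fluorine. Also open, as far as these compounds go, is how a single methoxy, a chlorine, a hydroxyl, a dimethylamino group or a carboxylic acid on this phenyl would read, and whether any group here gives a lower number than the fluorophenyl compounds.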